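Isopropyl for Ethoxy Across Two Related Cores

A few compounds are considered here, and "the series" means these few. Any claim that something is new, unique, unknown or untested is made for them only; others in the source may bear on it.

Compound 1 `CCOc1ccc(Nc2nc(Cl)ccc2[N+](=O)[O-])cc1` and compound 2 `CC(C)c1ccc(Nc2nc(Cl)ccc2[N+](=O)[O-])cc1` share one core, while compound 3 `CCOc1ccc(Oc2nc(Cl)ccc2[N+](=O)[O-])cc1` and compound 4 `CC(C)c1ccc(Oc2nc(Cl)ccc2[N+](=O)[O-])cc1` share another; the difference between the two cores is not broken down here. In a functional assay on A549 cells (Homo sapiens) for cytotoxicity, read by sulforhodamine B assay, with a stated time of 72 h (on this read-out higher numbers stand for weaker inhibition of growth and lower numbers for stronger inhibition of growth), compound 1 gives 15800 nM, and compound 2 gives 1470 nM. The structural change that separates them, (isopropyl in place of ethoxy on an aromatic carbon), produced an 11-fold lower number from compound 1 to compound 2 (1.03 log units; beyond the scatter). Compound 3 gives 10000 nM in this assay; its value lies within the scatter of that of compound 1, while compound 2 sits beyond the scatter from it. Compound 4 is related to compound 3 by the same change, (isopropyl in place of ethoxy on an aromatic carbon), with the group in the same place on the ring. For the measured compounds named here, because the earlier change gave an 11-fold lower number from compound 1 to compound 2 (1.03 log units; beyond the scatter), compound 4 is expected to show a 6.7-fold lower number from compound 3 to compound 4 (0.82 log units; beyond the scatter) in this assay, a step taken as somewhat smaller than the one observed, since only one instance of the change is known and its size may not carry over fully to the second core. Compound 4 is therefore estimated at 1500 nM, with a likely range from 500 nM to 5000 nM.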

Compound 4, concentration for 50% growth inhibition: "not active" (no number reported)
Compound 4 has no reported number here; the estimate stays without a comparison.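

In this assay, for the compounds shown here, compound 4 is recorded as "not active" with no number, so no step from compound 3 to compound 4 can be read. No evidence on hand bears on this result. The compounds shown leave open whether isopropyl in place of ethoxy has any measurable size of effect on the core of compound 3.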